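A few compounds are considered here, and "the series" means these few. Any claim that something is new, unique, unknown or untested is made for them only; others in the source may bear on it.

Three compounds built on one shared core were tested in a functional assay on HepG2 cells (Homo sapiens) for antiproliferative activity, read by MTT assay, with a stated time of 48 h; a higher number here means a weaker inhibitor, a lower number a stronger inhibitor. Compound 1 `CC(=O)Nc1ccc(-n2nncc2CN2C(=O)C3(C(C#N)=C(N)Oc4c(N)cc5nc6ccccc6nc5c43)c3ccccc32)cc1` carries an acetamido group on an aromatic carbon; in this assay compound 1 gives only a limit of the assay, > 50000 nM. Compound 2 `CCOc1ccc(-n2nncc2CN2C(=O)C3(C(C#N)=C(N)Oc4c(N)cc5nc6ccccc6nc5c43)c3ccccc32)cc1` has ethoxy in place of acetamido on an aromatic carbon, and in this assay compound 2 also gives only a limit, > 50000 nM. Compound 3 `N#CC1=C(N)Oc2c(N)cc3nc4ccccc4nc3c2C12C(=O)N(Cc1cnnn1-c1ccc([N+](=O)[O-])cc1)c1ccccc12` has nitro in place of acetamido on an aromatic carbon; in this assay compound 3 likewise gives only a limit, > 50000 nM. Compound 3 thus stands where every measured value sits, at the limit of > 50000 nM in this assay, at which 3 of the 3 values shown sit. The steps between the three, a step that the two limits leave unreadable from compound 1 to compound 2, a step that the two limits leave unreadable from compound 1 to compound 3 and a step that the two limits leave unreadable from compound 2 to compound 3, have no readable size, since each joins two limits.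

Compound 4 `Cc1ccc(Cl)cc1-n1nncc1CN1C(=O)C2(C(C#N)=C(N)Oc3c(N)cc4nc5ccccc5nc4c32)c2ccccc21` differs from compound 3 by 5-chloro-2-methylphenyl in place of 4-nitrophenyl on an aromatic nitrogen. Going by the values given here, no measured step tells how a change on this aromatic nitrogen shifts the result, so the expectation for compound 4 in this assay rests only on compound 3 sitting at the limit of > 50000 nM in this assay, at which 3 of the 3 values shown sit. The step from compound 3 to compound 4 is expected to be a number no higher from compound 3 to compound 4 (the limit leaves the size open). Compound 4 is therefore expected to give about 50000 nM in this assay, within a range from 5000 nM to 100000 nM, and most likely again only a limit.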

Compound 4, half-maximal inhibitory concentration: 17300 nM
Estimate against measurement, compound 4: 2.9-fold (0.46 log units) above; low and high end bracket the measured number.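

In this assay, going by these compounds alone, the group on the aromatic nitrogen of the five-membered ring is the first place on the shared core where a change can be read as a real shift: 5-chloro-2-methylphenyl in place of 4-nitrophenyl gives an at least 2.8-fold lower number from compound 3 to compound 4 (0.46 log units; beyond the scatter) and brings the series off the limit of the assay. From the compounds shown here alone, the same comparison holds against the other two aryl groups, with an at least 2.8-fold lower number from compound 2 to compound 4 (0.46 log units; beyond the scatter) when 4-ethoxyphenyl leaves and an at least 2.8-fold lower number from compound 1 to compound 4 (0.46 log units; beyond the scatter) when 4-acetamidophenyl leaves, and each of these steps starts from a limit, so its full size stays open. The steps among compound 1, compound 2 and compound 3 cannot be read, and compound 4 is the only one of the four with a number: the limit of > 50000 nM in this assay, at which 3 of the 4 values shown sit.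

The entering group differs from the others in both its chlorine and its methyl, so the compounds shown cannot tell which of the two matters, or whether both are needed. A plain phenyl ring, a ring bearing only the chlorine or only the methyl, or a ring carrying an amine or a carboxylic acid would show how far this shift extends.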